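Bcl-2 binding series: catechol for dimethoxy swap on the aryl ether

A few compounds are considered here, and "the series" means these few. Any claim that something is new, unique, unknown or untested is made for them only; others in the source may bear on it.

Measured so far, in an assay for binding affinity to Apoptosis regulator Bcl-2 (Homo sapiens), read by fluorescence polarization, with stated times of 30 min and 20 min, tested at 100 uM; on this read-out lower numbers stand for less inhibition and higher numbers for more inhibition at the one concentration tested (going by the name of the read-out):
- compound 1, `O=C(Nc1cc(C(F)(F)F)cc(C(F)(F)F)c1)N1CCN(S(=O)(=O)c2sccc2-c2ccccc2Oc2ccc(O)c(O)c2)CC1`, gives 7%
- compound 2, `COc1ccc(Oc2ccccc2-c2ccsc2S(=O)(=O)N2CCN(C(=O)Nc3cc(C(F)(F)F)cc(C(F)(F)F)c3)CC2)cc1OC`, gives 23%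
- compound 3, `COc1ccc(Oc2ccccc2-c2ccsc2S(=O)(=O)N2CCN(C(=O)Nc3ccc([N+](=O)[O-])cc3)CC2)cc1OC`, gives 17%

Compound 2 and compound 1 differ in one place: 3,4-dihydroxyphenyl in place of 3,4-dimethoxyphenyl on an oxygen on an aromatic ring. This change made a step of a number 16 percentage points lower from compound 2 to compound 1 (beyond the scatter). Compound 3 and compound 2 share the urea-piperazine-sulfonyl-thiophene framework but carry different anilines on the urea; the difference between the two cores is not broken down here. In this assay compound 3 and compound 2 sit within the scatter of each other, as do compound 3 and compound 1.

Compound 4, `O=C(Nc1ccc([N+](=O)[O-])cc1)N1CCN(S(=O)(=O)c2sccc2-c2ccccc2Oc2ccc(O)c(O)c2)CC1`, is not yet measured. It differs from compound 3 in the same way that compound 1 differs from compound 2: 3,4-dihydroxyphenyl in place of 3,4-dimethoxyphenyl on an oxygen on an aromatic ring. The place is identical in both pairs. The expected step from compound 3 to compound 4 is a number 13 percentage points lower from compound 3 to compound 4 (beyond the scatter), which rests on the step from compound 2 to compound 1, a number 16 percentage points lower from compound 2 to compound 1 (beyond the scatter), applied to compound 3 at 17%. Compound 4 is therefore estimated at 4%, between -6% and 15%.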

Compound 4, a percentage reported as inhibition, at one concentration (the size of the read-out at that concentration, not a potency): 33%
Compound 4: middle estimate off by 29 percentage points, on the low side; the measured number lies above the stated range.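

In this assay, putting 3,4-dihydroxyphenyl in place of 3,4-dimethoxyphenyl on the core carrying the nitro aniline gives a number 16 percentage points higher from compound 3 to compound 4 (beyond the scatter), so the step seen on the core carrying the trifluoromethyl aniline cannot be carried across as a fixed increment. The two steps disagree in direction as well as in number: the same change on two cores in this assay, a number 16 percentage points lower (beyond the scatter) from compound 2 to compound 1 and a number 16 percentage points higher (beyond the scatter) from compound 3 to compound 4, 32 percentage points apart, beyond the scatter of two such steps. This shows that, within these four compounds, the effect of the change depends on the core; it does not show what produces that dependence, and with one pair per core and readings at one concentration, it gives no general rule and no measure of potency.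

Whether the direction of the step follows the aniline on the urea remains open, since only one pair is shown for each aniline. A nitrile or carboxylic acid on the aniline, carried through both the dimethoxy and dihydroxy forms, would test whether either step recurs.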